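Benzyl on the triazole nitrogen of the isopropyl-pyrazole amide series

The compounds below may be only part of what the source reports. "The series", "measured", "known", "first", "only" and "open" are said of these compounds alone.

Working notes. The series is followed in a functional assay on PC-3 cells (Homo sapiens) for inhibition, read by MTT assay, with a stated time of 72 h; on this read-out higher numbers stand for weaker inhibition and lower numbers for stronger inhibition. Compound 1 `Cc1ccc(-n2cc(CNC(=O)c3cccc4c3cnn4C(C)C)nn2)cc1C` gives 23400 nM; compound 2 `Cc1cccc(-n2cc(CNC(=O)c3cccc4c3cnn4C(C)C)nn2)c1` gives 32300 nM; the step of a 1.4-fold higher number from compound 1 to compound 2 (0.14 log units; within the scatter) leaves the two within the scatter of each other, so neither stands apart. Compound 3 `CC(C)n1ncc2c(C(=O)NCc3cn(-c4ccccc4F)nn3)cccc21` returns only a limit, > 40000 nM, and no number.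

The unmeasured compound 4 `CC(C)n1ncc2c(C(=O)NCc3cn(Cc4ccccc4)nn3)cccc21` differs from compound 1 as follows: benzyl in place of 3,4-dimethylphenyl on an aromatic nitrogen.

Two measured steps change the group on the same aromatic nitrogen. From the compounds shown here alone, the step of an at least 1.7-fold higher number from compound 1 to compound 3 (0.23 log units; that floor lies within the scatter) and the step of an at least 1.2-fold higher number from compound 2 to compound 3 (0.09 log units; that floor lies within the scatter) both end at the limit (the limit of > 40000 nM in this assay, at which 1 of the 3 values shown sits), so their true size is unknown and only a floor is known. The step of a 1.4-fold higher number from compound 1 to compound 2 (0.14 log units; within the scatter), which removes a methyl on an aromatic carbon, stays within the scatter. Replacing the whole aromatic group on this nitrogen has so far gone toward the limit; a benzyl with no methyl groups is expected to behave at best like compound 2 and possibly to reach the limit again.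

For compound 4 a value of 38000 nM is expected, within 16000 nM to 90000 nM, i.e. an expected step of a 1.6-fold higher number from compound 1 to compound 4 (0.21 log units; within the scatter).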

Compound 4, half-maximal inhibitory concentration: 4420 nM
Compound 4: middle estimate off by 8.6-fold (0.93 log units), on the high side, outside the stated range (below it).
By their numbers in this assay, from the lowest: compound 4; then compounds 1 and 2 (each within the scatter of the next). At a limit, above all of these: compound 3.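

In this assay, among the compounds shown here, benzyl is the only group on this aromatic nitrogen that gives a change beyond the scatter from the compounds with a directly attached methyl-substituted phenyl ring: a 5.3-fold lower number from compound 1 to compound 4 (0.72 log units; beyond the scatter) and a 7.3-fold lower number from compound 2 to compound 4 (0.86 log units; beyond the scatter), whereas a 1.4-fold higher number from compound 1 to compound 2 (0.14 log units; within the scatter) shows that removing one methyl from the phenyl ring does not separate those two compounds. For the compounds shown here, compound 3 stands at a limit, so an at least 9.0-fold lower number from compound 3 to compound 4 (0.95 log units; beyond the scatter) gives only a floor for the true size of this step: the limit of > 40000 nM in this assay, at which 1 of the 4 values shown sits. Across these four compounds, the one group that carries its aromatic ring on a carbon, and not directly on the aromatic nitrogen, gives the lowest number in this assay, so this position is more sensitive to the kind of group attached than the methyl step alone suggested.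

The compounds shown leave open whether the aromatic ring of benzyl is needed at all, which a plain butyl chain on the same nitrogen would test, and whether a longer chain such as 2-phenylethyl goes further. They also leave open how substituents on the benzyl ring, such as methyl, fluorine or an amine, change the number in this assay.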